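The compounds below may be only part of what the source reports. "The series", "measured", "known", "first", "only" and "open" are said of these compounds alone.

Compound 1 `ClCc1ccc(Cn2cnc3c(Cl)ncnc32)cc1`: 24000 nM
Compound 2 `Nc1nc(Cl)c2ncn(Cc3ccc(CCl)cc3)c2n1`: 72400 nM

In a functional assay on SF-295 cells (Homo sapiens) for cytotoxicity, read by sulforhodamine B assay, with a stated time of 48 h (on this read-out higher numbers stand for lower toxicity in this test and lower numbers for higher toxicity in this test), compound 2 gives 72400 nM, the highest of the two numbers recorded here; its nearest neighbour, compound 1, gives 24000 nM. Compound 3 `ClCc1ccc(Cn2cnc3c(Cl)nc(Cl)nc32)cc1` has not yet been measured. It differs from compound 2 by chloro in place of amino on an aromatic carbon. Going by the values given here, only one measured step bears on this change, and it does so indirectly: going from compound 1 to compound 2, an amino group replaced a hydrogen on the same aromatic carbon, and the number rose by a 3.0-fold higher number from compound 1 to compound 2 (0.48 log units; beyond the scatter). Chloro is neither hydrogen nor amino, so the closest guide is that swapping the group at this carbon shifted the number by a modest amount in that earlier step. A step of similar size back toward compound 1, or no step beyond the scatter, is therefore expected. Compound 3 is estimated at 35000 nM, with a range of 12000 nM to 100000 nM, corresponding to an expected step of a 2.1-fold lower number from compound 2 to compound 3 (0.32 log units; beyond the scatter).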

Compound 3, concentration lethal to 50% of the cells: 44700 nM
For compound 3 the middle estimate is 1.3-fold (0.11 log units) below the measured one, within the range that was stated.
By their numbers in this assay, from the lowest: compounds 1, 3 and 2 (each within the scatter of the next, the first and the last beyond it).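

At this carbon, between two ring nitrogen atoms, putting chloro in place of amino gives a 1.6-fold lower number from compound 2 to compound 3 (0.21 log units; within the scatter) and putting chloro in place of hydrogen gives a 1.9-fold higher number from compound 1 to compound 3 (0.27 log units; within the scatter) so compound 3 cannot be told apart from either compound, although the step from hydrogen to amino, a 3.0-fold higher number from compound 1 to compound 2 (0.48 log units; beyond the scatter) stands beyond the scatter. The swap from amino to chloro removes a hydrogen-bond donor and a hydrogen-bond acceptor from the count, yet no shift beyond the scatter follows. Nothing measured here explains this result.

The compounds shown leave open whether a methoxy group or a longer chain such as butylamino at this carbon would move the number beyond the scatter. Also open, from the compounds shown here alone, is what a methylamino group would do in place of the chloro group meta to this carbon, which all three compounds share.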